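The source may report more compounds than this note shows. Statements on the series, on what has been measured and on what is new or still open speak of the compounds shown alone.

Compound 1 `N#CC1=C(N)Oc2c(N)cc3nc4ccccc4nc3c2C12C(=O)N(Cc1cnnn1-c1ccccc1Br)c1ccccc12` gives 27400 nM in a functional assay on A549 cells (Homo sapiens) for antiproliferative activity, read by MTT assay, with a stated time of 48 h; on this read-out lower numbers stand for stronger inhibition and higher numbers for weaker inhibition.
Compound 2 `COc1ccccc1-n1nncc1CN1C(=O)C2(C(C#N)=C(N)Oc3c(N)cc4nc5ccccc5nc4c32)c2ccccc21` gives 37500 nM in this assay.
Compound 3 `N#CC1=C(N)Oc2c(N)cc3nc4ccccc4nc3c2C12C(=O)N(Cc1cnnn1-c1ccc(Cl)cc1Cl)c1ccccc12` is reported in this assay only as a limit, > 50000 nM, not as a number.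

Compound 3 therefore stands at the weak end of what this assay can report, at the limit of > 50000 nM in this assay, at which 1 of the 3 values shown sits. Compound 4 `Cc1cc(C)c(-n2nncc2CN2C(=O)C3(C(C#N)=C(N)Oc4c(N)cc5nc6ccccc6nc5c43)c3ccccc32)c(C)c1` differs from it in one place: 2,4,6-trimethylphenyl in place of 2,4-dichlorophenyl on an aromatic nitrogen.

For the measured compounds named here, three measured steps concern exchanges of the aryl group on the same aromatic nitrogen. The step of an at least 1.8-fold higher number from compound 1 to compound 3 (0.26 log units; that floor lies within the scatter) and the step of an at least 1.3-fold higher number from compound 2 to compound 3 (0.12 log units; that floor lies within the scatter) each run toward the limit and stay within the scatter, and the step of a 1.4-fold higher number from compound 1 to compound 2 (0.14 log units; within the scatter) is also within the scatter. None of these exchanges moved the number in this assay beyond the scatter, so a further exchange of this aryl group is expected to produce no step beyond the scatter either; this amounts to an expected step that the limit leaves unreadable from compound 3 to compound 4. Compound 4 is accordingly estimated to come out near 60000 nM, within a range from 25000 nM to 150000 nM, and most likely again as a limit rather than a number.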

Compound 4, half-maximal inhibitory concentration: 12700 nM
The estimate for compound 4 lay 4.7-fold (0.67 log units) above the measured number, outside the stated range (below it).
By their numbers in this assay, from the lowest: compound 4; then compounds 1 and 2 (each within the scatter of the next). At a limit, above all of these: compound 3.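

In this assay, this exchange shows that the aryl group on the aromatic nitrogen can move the number beyond the scatter, which none of the exchanges among compounds 1, 2 and 3 had done: the change to 2,4,6-trimethylphenyl gives a 3.0-fold lower number from compound 2 to compound 4 (0.47 log units; beyond the scatter) and a 2.2-fold lower number from compound 1 to compound 4 (0.33 log units; beyond the scatter), both modest. Compound 4 is thus the most potent of the four here, and the third step, an at least 3.9-fold lower number from compound 3 to compound 4 (0.59 log units; beyond the scatter), gives only a floor for the size of the change. Compound 3 stands at a limit of the assay rather than at a number: the limit of > 50000 nM in this assay, at which 1 of the 4 values shown sits.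

The compounds shown leave open whether a single methyl group, as in 4-methylphenyl or 2-methylphenyl, would produce a similar step, or whether 2,6-dimethylphenyl would suffice. As far as these compounds go, how an unsubstituted phenyl or an aminophenyl would behave at this position also remains open.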